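The source may hold more compounds than are shown below. What is called first, only, known or untested is meant among the compounds shown, and "the series" means these compounds.

Compound 1 `COc1ccc(-c2cc(Cn3cc(-c4cc(C)c(C)cc4C)nn3)on2)cc1OC` reads > 500000 nM
Compound 2 `COc1cc(OC)cc(-c2cn(Cc3cc(-c4ccc(OC)c(OC)c4)no3)nn2)c1` reads > 500000 nM

In an ADME assay on THP-1 cells (Homo sapiens) for cytotoxicity, read by MTT assay, with a stated time of 72 h (a higher number here means that more compound is tolerated, a lower number that less compound is tolerated), compound 2 gives > 500000 nM as a limit of the assay and not a number. Compound 1 gives > 500000 nM as a limit too. The picture so far is the limit of > 500000 nM in this assay, at which 2 of the 2 values shown sit, and neither compound has an exact figure. Compound 3 `COc1ccc(-c2cn(Cc3cc(-c4ccc(OC)c(OC)c4)no3)nn2)cc1` differs from compound 2 in one place. The change is 4-methoxyphenyl in place of 3,5-dimethoxyphenyl on an aromatic carbon and it puts 4-methoxyphenyl in place of 3,5-dimethoxyphenyl on an aromatic carbon of a five-membered aromatic ring with 3 nitrogen. Within the data shown here, the only measured step that bears on this is a step that the two limits leave unreadable from compound 1 to compound 2 and it brought in 3,5-dimethoxyphenyl in place of 2,4,5-trimethylphenyl on an aromatic carbon. With no readable size to go on, no change beyond the scatter is expected, and no direction can be favoured. The expected move is a number no higher from compound 2 to compound 3 (the limit leaves the size open) on this reasoning. Compound 3 is estimated at 500000 nM with an expected range from 200000 nM to 1000000 nM. A limit of the assay is expected again for compound 3.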

Compound 3, half-maximal cytotoxic concentration: > 500000 nM
Compound 3 ended at the assay's limit; the forecaster's own chance of this, stated with the estimate: 80%; the middle value lies on the limit itself.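

Compound 1, compound 2 and compound 3 all stop at a limit of the assay, so no step among them can be read: the limit of > 500000 nM in this assay, at which 3 of the 3 values shown sit.

The compounds shown leave open how much of each compound the cells tolerate, and whether changing the substituted phenyl group on the shared core alters that at all.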